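This account rests on a few compounds, and the source may have more. Where it says the series, first, only, none or still open, it means among the compounds named here.

In a functional assay on CWR22R cells (Homo sapiens) for antiproliferative activity, read by MTT assay, with a stated time of 3 days (on this read-out lower numbers stand for stronger inhibition and higher numbers for weaker inhibition), compound 1 (`COc1cc(O)c2c(=O)cc(-c3ccc(NS(C)(=O)=O)cc3)oc2c1OC(C)C`) gives 3800 nM and compound 2 (`C=CC(=O)Nc1ccc(-c2cc(=O)c3c(O)cc(OC)c(OC(C)C)c3o2)cc1`) gives 5800 nM so compound 2 stands within the scatter of compound 1 (a 1.5-fold higher number from compound 1 to compound 2 (0.18 log units; within the scatter)). Compound 3 (`COc1cc(O)c2c(=O)cc(-c3ccc(NC(=O)NC4CC4)cc3)oc2c1OC(C)C`) has cyclopropylamino in place of vinyl on a carbonyl carbon. Among the measured compounds shown here, only that one measured step bears on this change, and it stayed within the scatter with a different group on the same nitrogen, so no step beyond the scatter is expected in this assay (a 1.3-fold lower number from compound 2 to compound 3 (0.11 log units; within the scatter)). For compound 3 the estimated value is 4500 nM (expected range 1800 nM to 11000 nM).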

Compound 3, half-maximal inhibitory concentration: 6700 nM
Estimate against measurement, compound 3: 1.5-fold (0.17 log units) below; low and high end bracket the measured number.
By their numbers in this assay, from the lowest: compounds 1, 2 and 3 (each within the scatter of the next).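

In this assay, the third group tried on this nitrogen also stays within the scatter: cyclopropylamino in place of vinyl on the carbonyl carbon gives a 1.2-fold higher number from compound 2 to compound 3 (0.06 log units; within the scatter), and cyclopropylcarbamoyl in place of methylsulfonyl gives a 1.8-fold higher number from compound 1 to compound 3 (0.25 log units; within the scatter). So a three-membered ring and a hydrogen-bond donor, absent from the vinyl group, bring no step beyond the scatter here. No measurement shown explains this flatness. As far as these compounds go, whether a dimethylamino or morpholine group on that carbonyl carbon, or a free amine on the aromatic ring, would step beyond the scatter remains open.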